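This account rests on a few compounds, and the source may have more. Where it says the series, first, only, none or still open, it means among the compounds named here.

Compound 1, `CNC(=O)c1cc(C(=O)N[C@H]2[C@@H]3C[C@H](O)C[C@@H]32)n([C@@H](C)c2cccc(Cl)c2)n1`: 333 nm/s
Compound 2, `CNC(=O)c1cc(C(=O)N[C@H]2CC[C@H](O)CC2)n([C@@H](C)c2cccc(Cl)c2)n1`: 235 nm/s
Compound 3, `CNC(=O)c1cc(C(=O)N[C@H]2CC[C@H](O)CC2)c([C@@H](C)c2cccc(C)c2)o1`: 85 nm/s

These three compounds were measured in an ADME assay for permeability; a higher number here means that the compound crosses the layer faster, a lower number that the compound crosses the layer more slowly. Compound 3 gives the lowest of the three numbers: compound 2 stands above it by a gap beyond the usual scatter, and compound 1 stands further above it still. Compound 4, `CNC(=O)c1cc(C(=O)N[C@H]2CC[C@H](O)CC2)c([C@@H](C)c2ccc(Cl)cc2)o1`, has not yet been measured. It differs from compound 3 in one place: 4-chlorophenyl in place of 3-methylphenyl on a saturated chain carbon bound to an aromatic carbon and a saturated chain carbon.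

Among the measured compounds shown here, the only step between measured compounds that differ in a single place is a 1.4-fold lower number from compound 1 to compound 2 (0.15 log units; within the scatter); that step exchanges the ring on the amide-type nitrogen and says nothing about the phenyl group on the saturated chain carbon. Compound 2 and compound 3 differ in more than one place at once, so their gap cannot be assigned to any single change. For the measured compounds named here, no measured step therefore bears directly on the change from compound 3 to compound 4. With nothing in the data pointing either way, the change is expected to stay within the scatter, which gives a 1.2-fold higher number from compound 3 to compound 4 (0.07 log units; within the scatter). For compound 4 the estimate is 100 nm/s, with an expected range from 45 nm/s to 220 nm/s.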

Compound 4, apparent permeability: 150 nm/s
For compound 4 the middle estimate is 1.5-fold (0.18 log units) below the measured one; low and high end bracket the measured number.
By their numbers in this assay, from the lowest: compounds 3, 4, 2 and 1 (each within the scatter of the next, the first and the last beyond it).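

Among the compounds shown here, putting 4-chlorophenyl in place of 3-methylphenyl on a saturated chain carbon bound to an aromatic carbon and a saturated chain carbon gives, in this assay, a 1.8-fold higher number from compound 3 to compound 4 (0.25 log units; within the scatter) and this is the first measured step at this position, as the earlier single-place step concerned only the ring on the amide-type nitrogen. In this read-out, then, the two groups cannot be told apart, although both the substituent on the phenyl ring and its place on that ring differ between them. No measurement shown offers a reason for the size of this step.

Since the substituent and its place change together, the compounds shown leave open what each contributes alone, a question that 4-methylphenyl or 3-chlorophenyl on this same core would address. They also leave open whether this position would remain as undemanding with a phenyl ring carrying an amine or a carboxylic acid, or with a longer chain in place of the methyl on the saturated chain carbon.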